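The source may report more compounds than this note shows. Statements on the series, on what has been measured and on what is new or still open speak of the compounds shown alone.

Going by the values given here, the three compounds measured so far share one core and differ in the group hung on the far amide. Compound 1, `CC(NC(=O)c1cccc(-c2ccc(NC(=O)Nc3ccc(Cl)c(C(F)(F)F)c3)cc2)c1)c1ccccc1`, gives 5670 nM in a functional assay on HepG2 cells (Homo sapiens) for inhibition, read by MTT assay, with a stated time of 120 h; a lower number here means a stronger inhibitor, a higher number a weaker inhibitor. Compound 3, `CC(NC(=O)c1ccc(-c2ccc(NC(=O)Nc3ccc(Cl)c(C(F)(F)F)c3)cc2)cc1)c1ccccc1`, gives 16800 nM in this assay, and compound 2, `CC(NC(=O)C#Cc1ccc(NC(=O)Nc2ccc(Cl)c(C(F)(F)F)c2)cc1)c1ccccc1`, gives 20500 nM. Compound 1 therefore stands lowest of the three numbers, and its gap to compound 3 and to compound 2 lies beyond the usual scatter, so it is the strongest inhibitor among them.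

Compound 4, `CNC(=O)c1cccc(-c2ccc(NC(=O)Nc3ccc(Cl)c(C(F)(F)F)c3)cc2)c1`, differs from compound 1 in one place: methyl in place of 1-phenylethyl on an amide-type nitrogen. Among the compounds with values here, no pair of measured compounds shows this kind of change, so the size of its effect in this assay is not known from the data. The expectation for compound 4 is a weaker inhibitor than compound 1, with a step of a 2.6-fold higher number from compound 1 to compound 4 (0.42 log units; beyond the scatter) that is estimated to lie beyond the scatter. Compound 4 is thus expected to give about 15000 nM in this assay, with a range from 5000 nM to 45000 nM.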

Compound 4, half-maximal inhibitory concentration: 37100 nM
Beside the measured number, compound 4's estimate is 2.5-fold (0.39 log units) below it; the range from low to high includes it.
By their numbers in this assay, from the lowest: compound 1; then compounds 3, 2 and 4 (each within the scatter of the next, the first and the last beyond it).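

In this assay, replacing 1-phenylethyl with methyl on the amide-type nitrogen gives a 6.5-fold higher number from compound 1 to compound 4 (0.82 log units; beyond the scatter). Going by these compounds alone, this is the first step at a single place, and it shows that the group on this nitrogen matters: the smaller methyl, which carries no six-membered aromatic ring, gives the weaker inhibitor of this pair. Nothing measured on these compounds says why the number moves.

The compounds shown leave open whether the ring or the rest of the 1-phenylethyl group carries this step, and whether benzyl or a longer chain such as propyl would stay close to compound 1 or to compound 4. From the compounds shown here alone, it also remains open whether the same exchange would give a step of similar size on compound 3 or compound 2.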